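Replacing the aryl amide group: compound 1 to compound 4

A few compounds are considered here, and "the series" means these few. Any claim that something is new, unique, unknown or untested is made for them only; others in the source may bear on it.

Of the compounds shown here, three have been tested in an assay on HEK293 cells for displacement of a labelled ligand from metabotropic glutamate receptor 5 (Rattus norvegicus); a higher number here means a weaker inhibitor, a lower number a stronger inhibitor. Among the measured compounds shown here, compound 1 `COc1ccc(C(=O)Nc2cc(-c3ccccc3)nn2-c2ccccc2)cc1` gives 420 nM in this assay, the only single number among the three, so it serves as the reference point for the series. Compound 2 `O=C(Nc1cc(-c2ccccc2)nn1-c1ccccc1)c1cc([N+](=O)[O-])cc([N+](=O)[O-])c1` has "not determined" (no result reported) in this assay. For compound 3 `O=C(Nc1cc(-c2ccccc2)nn1-c1cccc(Br)c1)c1ccccc1` this assay reports only a limit, > 10000 nM, not a number. That entry sits at the limit of > 10000 nM in this assay, at which 1 of the 3 values shown sits.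

Compound 4 `O=C(Nc1cc(-c2ccccc2)nn1-c1ccccc1)C1=CCCCC1` has not yet been measured. It differs from compound 1 by cyclohex-1-en-1-yl in place of 4-methoxyphenyl on a carbonyl carbon. For the measured compounds named here, no pair of measured compounds differs at that position alone, so the size of this step has no precedent. The expected step is a 6.0-fold higher number from compound 1 to compound 4 (0.77 log units; beyond the scatter), in the direction of weaker binding, clearly beyond the usual scatter. Compound 4 is accordingly estimated at 2500 nM in this assay, with a plausible range of 600 nM to 10000 nM.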

Compound 4, inhibition constant: 4470 nM
The estimate for compound 4 lay 1.8-fold (0.25 log units) below the measured number; measured number inside the range.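

Replacing 4-methoxyphenyl with cyclohex-1-en-1-yl on a carbonyl carbon gives an 11-fold higher number from compound 1 to compound 4 (1.03 log units; beyond the scatter) in this assay, so this position is not indifferent to the group it carries. Compound 4 still gives a single number, 4470 nM, which shows that a non-aromatic ring of carbon only leaves binding measurable in this series, though weaker than with 4-methoxyphenyl. The data shown give no cause for this step.

Since the ring and the oxygen leave together, the compounds shown do not separate the contribution of the aromatic ring from that of the methoxy group. Plain phenyl, cyclohexyl or 4-hydroxyphenyl on the same carbonyl carbon, with the rest of compound 1 unchanged, would address that question.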